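The compounds below may be only part of what the source reports. "The series", "measured", "known", "first", "only" and "open" are said of these compounds alone.

Compound 1 `COc1cccc(N2C(=O)CS/C2=N\c2csc(-c3ccccc3)c2)c1` has no result in a functional assay on HCT-116 cells (Homo sapiens) for cytotoxicity, read by MTT assay, with a stated time of 72 h; on this read-out higher numbers stand for weaker inhibition and lower numbers for stronger inhibition: in this assay compound 1 gives "not determined" (no result reported). Within the data shown here, compound 2 `COc1cccc(N2C(=O)CS/C2=N\c2csc(-c3ccc(C)cc3)c2)c1` is the only member with a number here: in this assay compound 2 gives 41000 nM. Compound 3 `COc1cccc(N2C(=O)CS/C2=N\c2csc(-c3ccc(Cl)cc3)c2)c1` is not yet measured. It differs from compound 2 by chloro in place of methyl on an aromatic carbon — chloro in place of methyl on an aromatic carbon. Among the measured compounds shown here, no measured step of this kind is available, so the expected step is small, if any, and most likely within the scatter, leaning slightly toward stronger inhibition: the expected step is a 1.4-fold lower number from compound 2 to compound 3 (0.14 log units; within the scatter). Compound 3 is estimated at 30000 nM, with a range from 10000 nM to 90000 nM.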

Compound 3, half-maximal inhibitory concentration: > 50000 nM
Compound 3 ended at the assay's limit; the forecaster's own chance of this, stated with the estimate: 20%; middle value at least 1.6-fold (0.22 log units) away from the limit.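

Replacing methyl with chloro on the 4-substituted phenyl group gives an at least 1.2-fold higher number from compound 2 to compound 3 (0.08 log units; that floor lies within the scatter), so chloro brings no gain over methyl at this position in this assay. As far as these compounds go, compound 3 gives a limit of the assay, not a number: the limit of > 50000 nM in this assay, at which 1 of the 3 values shown sits. The true size of the step therefore stays unknown, and it cannot be said how far compound 3 lies from compound 2.

From the compounds shown here alone, whether an amine or a carboxylic acid at this position would give a lower number remains open. So does the effect of changing the methoxy group on the other aromatic ring.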